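The source may hold more compounds than are shown below. What is called first, only, known or untested is meant among the compounds shown, and "the series" means these compounds.

The compounds share one core, a benzofuran-type amidoxime attached to a substituted phenyl ring, and each was tested in an assay on isolated protein for inhibition of Indoleamine 2,3-dioxygenase 1 (Homo sapiens), read by spectrophotometry; on this read-out higher numbers stand for weaker inhibition and lower numbers for stronger inhibition. Compound 1 `O/N=C(/Nc1cccc(Cl)c1)c1ccc2occc2c1` gives 690 nM in this assay, the lowest of the two numbers reported. Compound 2 `O/N=C(/Nc1ccc(F)c(Cl)c1)c1ccc2occc2c1`, which carries an extra fluorine on the phenyl ring, gives 5200 nM, so that a 7.5-fold higher number from compound 1 to compound 2 (0.88 log units; beyond the scatter). Compound 3 `Cc1ccc(N/C(=N/O)c2ccc3occc3c2)cc1C`, with two methyl groups on that ring, reaches only a limit of the assay, > 30000 nM; this is the limit of > 30000 nM in this assay, at which 1 of the 3 values shown sits.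

Compound 4 `CC(=O)c1cccc(N/C(=N/O)c2ccc3occc3c2)c1` has not yet been measured. It differs from compound 1 in one place: acetyl in place of chloro on an aromatic carbon, meta to a large group. Among the measured compounds shown here, no measured step swaps one group for another in this way; the only steps available add a group to the ring, and both the fluoro step from compound 1 to compound 2 and the dimethyl pattern of compound 3 point toward weaker inhibition. On this thin basis compound 4 is expected to land somewhat weaker than compound 1, with a 2.9-fold higher number from compound 1 to compound 4 (0.46 log units; beyond the scatter), and its estimated value in this assay is 2000 nM, within a range of 500 nM to 10000 nM.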

Compound 4, half-maximal inhibitory concentration: > 30000 nM
Compound 4: a limit, no number; the forecaster's own chance of this, stated with the estimate: 10%; at least 15-fold (1.17 log units) between middle value and limit.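

Replacing chloro with acetyl on this aromatic carbon, meta to a large group, is the first change shown that exchanges one group for another instead of adding a group to the ring, and in this assay it gives an at least 43-fold higher number from compound 1 to compound 4 (1.63 log units; beyond the scatter). As far as these compounds go, compound 4 gives > 30000 nM, which is a limit of the assay and not a number, so this step marks only the smallest loss that fits the data, and the true size of the loss stays unknown. This shows that inhibition in the series depends strongly on what occupies this one place, but readings at the limit cannot be ranked against each other, and compound 4 is not the only one there: the limit of > 30000 nM in this assay, at which 2 of the 4 values shown sit.

The compounds shown leave open whether the loss goes with the carbonyl of the acetyl or simply with the larger number of heavy atoms that enter in place of the single chlorine. A methyl, a methoxy, a nitrile or an amine on this same carbon would help to separate these two readings and show how much room for change this place allows.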